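Moving a fluorine on the phenyl ring: a repeated change

The source may hold more compounds than are shown below. What is called first, only, known or untested is meant among the compounds shown, and "the series" means these compounds.

Of the compounds shown here, three have been tested in a functional assay on HL-60 cells (Homo sapiens) for inhibition, read by MTT assay, with a stated time of 72 h; a lower number here means a stronger inhibitor, a higher number a weaker inhibitor. Compound 1 `CCc1nc(-c2ccccc2F)c(C(=O)N2CCN(c3cccc(Cl)c3)CC2)o1` gives 139 nM. Compound 3 `CCc1nc(-c2ccc(F)cc2)c(C(=O)N2CCN(c3cccc(Cl)c3)CC2)o1` gives 169 nM. These two share one core, and the difference between them is 4-fluorophenyl in place of 2-fluorophenyl on an aromatic carbon. That change made a step of a 1.2-fold higher number from compound 1 to compound 3 (0.08 log units; within the scatter), so the two numbers are not told apart by this measurement.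

Compound 2 `Cc1nc(-c2ccccc2F)c(C(=O)N2CCN(c3cc(Cl)cc(Cl)c3)CC2)o1` has a different core, and how its core differs from that of compound 1 is not broken down here. In this assay compound 2 gives 60.2 nM, the lowest of the three numbers; its steps to compound 1 and to compound 3 both lie beyond the scatter, so it is the strongest inhibitor among the measured compounds.

Compound 4 `Cc1nc(-c2ccc(F)cc2)c(C(=O)N2CCN(c3cc(Cl)cc(Cl)c3)CC2)o1` has not yet been measured. It differs from compound 2 by 4-fluorophenyl in place of 2-fluorophenyl on an aromatic carbon. Within the data shown here, this is the same kind of change as the one from compound 1 to compound 3, not the same change: in compound 2 the place lies two ring bonds from the ring atom that bears a methyl group, whereas in compound 1 it lies two ring bonds from the ring atom that bears an ethyl group.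

Because the earlier step was a 1.2-fold higher number from compound 1 to compound 3 (0.08 log units; within the scatter), a step of similar size is expected here, namely a 1.2-fold higher number from compound 2 to compound 4 (0.08 log units; within the scatter). On that basis compound 4 is estimated to give 72 nM in this assay, most likely between 38 nM and 135 nM. Among the measured compounds shown here, the single earlier example is a thin basis, and the measurement will show whether the expectation holds.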

Compound 4, half-maximal inhibitory concentration: 52.1 nM
Compound 4: middle estimate off by 1.4-fold (0.14 log units), on the high side; measured number inside the range.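

In this assay, replacing 2-fluorophenyl with 4-fluorophenyl gave a 1.2-fold lower number from compound 2 to compound 4 (0.06 log units; within the scatter), so this measurement does not tell compound 2 and compound 4 apart. Set beside the earlier case, the change looks the same on both cores as far as this assay can tell: the same change on two cores in this assay, a 1.2-fold higher number (0.08 log units; within the scatter) from compound 1 to compound 3 and a 1.2-fold lower number (0.06 log units; within the scatter) from compound 2 to compound 4, 1.4-fold (0.15 log units) apart, within the scatter of two such steps. The two steps point in opposite directions on paper, but both are too small for that to carry any meaning, so in these two pairs moving the fluorine made no readable difference; this does not show that the same would hold on any other core, and two pairs say nothing about why the numbers stay so close.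

The compounds shown leave open whether the phenyl ring needs a fluorine at all, and what a plain phenyl, a 4-chlorophenyl or a 4-methoxyphenyl would give in place of the fluorophenyl groups. They also leave open what a longer chain, such as propyl, would give on the ring atom that bears the methyl group in compound 2 and compound 4.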